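Taking the chloro off compound 2

The compounds below may be only part of what the source reports. "The series", "measured", "known", "first", "only" and "open" are said of these compounds alone.

In a functional assay on MCF7 cells (Homo sapiens) for antiproliferative activity, read by MTT assay, with a stated time of 48 h (a higher number here means a weaker inhibitor, a lower number a stronger inhibitor), compound 1 (`COc1ccc(-c2nc(C)c(C(=O)CSc3nc(N)c(C#N)c(-c4ccccc4)n3)s2)cc1`) gives 72100 nM and compound 2 (`Cc1nc(-c2ccccc2)sc1C(=O)CSc1nc(N)c(C#N)c(-c2ccc(Cl)cc2)n1`) gives 20200 nM. Compound 2 holds the lower of these two numbers, and its gap to compound 1 lies beyond the scatter. Going by the values given here, these two compounds differ in more than one place, so no measured single-place step is available to size the next change.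

Compound 3 (`Cc1nc(-c2ccccc2)sc1C(=O)CSc1nc(N)c(C#N)c(-c2ccccc2)n1`) comes from compound 2 through hydrogen in place of chloro on an aromatic carbon, 4-chlorophenyl to phenyl. A modest rise in the number is expected, meaning a somewhat weaker inhibitor, and this rests only on compound 1, which also lacks the chloro, at 72100 nM. The estimated change is a 1.7-fold higher number from compound 2 to compound 3 (0.24 log units; within the scatter), and it may not clear the scatter by much. For compound 3 the estimated value is 35000 nM, with an expected range of 14000 nM to 85000 nM.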

Compound 3, half-maximal inhibitory concentration: 30100 nM
For compound 3 the middle estimate is 1.2-fold (0.07 log units) above the measured one; measured number inside the range.
By their numbers in this assay, from the lowest: compounds 2 and 3 (each within the scatter of the next); then compound 1.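

In this assay the chloro position now has its first single-place step: 4-chlorophenyl to phenyl gives a 1.5-fold higher number from compound 2 to compound 3 (0.17 log units; within the scatter) and so does not separate the two compounds. The place carrying the methoxy gives a step that can be read, with loss of the methoxy group giving a 2.4-fold lower number from compound 1 to compound 3 (0.38 log units; beyond the scatter) and clearing the scatter, though only modestly. No measurement bearing on the reason for the size of either step is available.

Going by these compounds, whether an amine, a carboxylic acid or a fluoro group at the chloro position would separate from hydrogen and chloro remains open. Also open, on these data alone, is whether the methoxy step holds when the chloro group is present on the other aromatic ring.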